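The source may hold more compounds than are shown below. What is called first, only, known or untested is meant among the compounds shown, and "the series" means these compounds.

Of the compounds shown here, three that share one core have been measured in an assay for binding affinity to dual specificity mitogen-activated protein kinase kinase 4 (Homo sapiens), read by KINOMEscan, tested at 100 nM; on this read-out lower numbers stand for a stronger effect and higher numbers for a weaker effect at the one concentration tested. Compound 1 `CCCS(=O)(=O)Nc1ccc(F)c(C(=O)c2n[nH]c3ncc(-c4ccccc4F)cc23)c1F` gives 2%. Compound 2 `CCCS(=O)(=O)Nc1ccc(F)c(C(=O)c2n[nH]c3ncc(-c4ccccc4O)cc23)c1F` gives 9%. Compound 3 `CCCS(=O)(=O)Nc1ccc(F)c(C(=O)c2n[nH]c3ncc(-c4ccc(Cl)c(Cl)c4)cc23)c1F` gives 45%. Among these three numbers compound 2 stands second highest: its nearest neighbour is compound 1, separated by a number 7 percentage points higher from compound 1 to compound 2 (within the scatter), while compound 3 lies furthest away, separated by a number 36 percentage points higher from compound 2 to compound 3 (beyond the scatter).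

The next compound, compound 4 `CCCS(=O)(=O)Nc1ccc(F)c(C(=O)c2n[nH]c3ncc(-c4cccc(C(F)(F)F)c4)cc23)c1F`, differs from compound 2 in one place: 3-(trifluoromethyl)phenyl in place of 2-hydroxyphenyl on an aromatic carbon. The measured step that bears most directly on this change is a number 36 percentage points higher from compound 2 to compound 3 (beyond the scatter), in which the same 2-hydroxyphenyl was removed from the same position and a differently substituted phenyl put in, with a large rise in the number. The step of a number 43 percentage points higher from compound 1 to compound 3 (beyond the scatter) points the same way. Among the compounds with values here, because a number 36 percentage points higher from compound 2 to compound 3 (beyond the scatter) was large, a rise beyond the scatter is expected for compound 4 as well, though the new group is not identical to the one in compound 3, so the size is uncertain. Compound 4 is therefore estimated at 35%, between 12% and 62%, an expected step of a number 26 percentage points higher from compound 2 to compound 4 (beyond the scatter).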

Compound 4, a percentage reported as activity, at one concentration (the size of the read-out at that concentration, not a potency): 57%
The estimate for compound 4 lay 22 percentage points below the measured number; the range from low to high includes it.
By their numbers in this assay, from the lowest: compounds 1 and 2 (each within the scatter of the next); then compound 3; then compound 4.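

In this assay the 3-(trifluoromethyl)phenyl group gives a number 48 percentage points higher from compound 2 to compound 4 (beyond the scatter) and a number 55 percentage points higher from compound 1 to compound 4 (beyond the scatter) as large steps, so a second group with a substituent named at ring position 3 now reads well above the 2-fluorophenyl and 2-hydroxyphenyl compounds. The two groups of that kind are not interchangeable either, since the swap from 3,4-dichlorophenyl gives a number 12 percentage points higher from compound 3 to compound 4 (beyond the scatter) as a modest step. Nothing measured here gives a reason for these rises.

From the compounds shown here alone, it stays open whether the trifluoromethyl group itself or its place on the ring matters more, a question that 2-(trifluoromethyl)phenyl would address. Going by these compounds, how a ring carrying an amine or a carboxylic acid would read at this position also remains unknown.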